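A chloro enters a compound that sits at a limit

This account rests on a few compounds, and the source may have more. Where it says the series, first, only, none or still open, it means among the compounds named here.

Compound 1 `COc1cc(-c2nn(-c3cccc(NC(=O)Nc4cc(C(F)(F)F)cc(C(F)(F)F)c4)c3)cc2-c2ccncc2)ccc1Cl` gives 24300 nM in a functional assay on MDA-MB-468 cells (Homo sapiens) for inhibition, read by sulforhodamine B assay, with a stated time of 48 h; on this read-out lower numbers stand for higher toxicity in this test and higher numbers for lower toxicity in this test. Compound 2 `COc1cc(-c2nn(-c3cccc(NC(=O)c4cccc(C(F)(F)F)c4)c3)cc2-c2ccncc2)ccc1Cl` is reported only as a limit in this assay, > 50000 nM, a case of the limit of > 50000 nM in this assay, at which 1 of the 2 values shown sits. Compound 3 `COc1cc(-c2nn(-c3cccc(NC(=O)c4ccc(Cl)c(C(F)(F)F)c4)c3)cc2-c2ccncc2)ccc1Cl` has not yet been measured. Compound 3 differs from compound 2 by chloro in place of hydrogen on an aromatic carbon. Within the data shown here, no step between two measured compounds is available here, so the step from compound 2 to compound 3 in this assay is expected to be small, an at least 1.1-fold lower number from compound 2 to compound 3 (0.04 log units; that floor lies within the scatter), and another limit is likely. Compound 3 is expected to give about 45000 nM, within 20000 nM to 100000 nM.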

Compound 3, concentration lethal to 50% of the cells: > 32500 nM
Compound 3: a limit, no number; the forecaster's own chance of this, stated with the estimate: 60%; the middle value lies beyond the limit too.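

Among these compounds, compound 2 and compound 3 are both reported only as limits in this assay, so no step between them can be read. Going by these compounds, whether chloro in place of hydrogen changes this read-out at all remains open.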